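Thiazole acetic acid series: aryl swap at the ring carbon

The source may report more compounds than this note shows. Statements on the series, on what has been measured and on what is new or still open speak of the compounds shown alone.

Measured compounds:
compound 1 `Cc1nc(-c2ccc(Cl)cc2)c(CC(=O)O)s1`, 41000 nM
compound 2 `O=C(O)Cc1sc(C(c2ccc(F)cc2)c2ccc(F)cc2)nc1-c1ccco1`, 140 nM
compound 3 `O=C(O)Cc1sc(C(c2ccccc2)c2ccccc2)nc1-c1cccc(F)c1`, 29 nM

In an in vitro functional assay on HEK285-7 cells for antagonist activity at prostaglandin D2 receptor 2 (Homo sapiens), read by BRET and beta-arrestin recruitment (on this read-out higher numbers stand for weaker inhibition and lower numbers for stronger inhibition), compound 1 gives 41000 nM, compound 2 gives 140 nM and compound 3 gives 29 nM. Compound 2 sits second highest of the three numbers; its nearest neighbour is compound 3, which lies lower by a margin beyond the scatter, and its furthest is compound 1, which lies higher by a margin far beyond the scatter. For the measured compounds named here, no two of the measured compounds differ in one place only, so no single step between measured compounds is known.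

Compound 4 `CN(C)c1cc(-c2nc(C(c3ccc(F)cc3)c3ccc(F)cc3)sc2CC(=O)O)ccn1` is not yet measured. It differs from compound 2 in one place: 2-(dimethylamino)pyridin-4-yl in place of furan-2-yl on an aromatic carbon.

Going by the values given here, the only guide is that compound 3, which carries a six-membered aromatic ring at the same position, gives 29 nM against 140 nM for compound 2, but those two also differ elsewhere, so that comparison is not clean. A modest move toward lower numbers, around the edge of the scatter, is expected for the step of a 1.8-fold lower number from compound 2 to compound 4 (0.24 log units; within the scatter) in this assay. Compound 4 is accordingly estimated at 80 nM, within a range from 20 nM to 320 nM.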

Compound 4, half-maximal inhibitory concentration: > 100000 nM
Compound 4 was reported as a limit; the forecaster's own chance of this, stated with the estimate: 3%; middle value at least 1200-fold (3.09 log units) from the limit.
By their numbers in this assay, from the lowest: compound 3; then compound 2; then compound 1. At a limit, above all of these: compound 4.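

In this assay, compound 4 is reported only as a limit, not as a number: > 100000 nM. For the compounds shown here, with the rest of compound 2 unchanged, 2-(dimethylamino)pyridin-4-yl in place of furan-2-yl gives an at least 710-fold higher number from compound 2 to compound 4 (2.85 log units; beyond the scatter), the first step that differs in one place and a large one. Going by these compounds alone, this shows that the group on this aromatic carbon, next to the ring nitrogen and next to the ring atom that bears a carboxymethyl group, can alone decide the read-out, something the earlier compounds, which differ in more than one place, could not show, and the full size of the step remains unknown: the limit of > 100000 nM in this assay, at which 1 of the 4 values shown sits.

The compounds shown do not separate the contribution of the pyridine ring from that of the dimethylamino group, a question that a plain phenyl, an unsubstituted pyridin-4-yl or a primary amine in place of the dimethylamino group would address. Also open, going by these compounds, is how the fluorophenyl group of compound 3 would read at this position with the rest of compound 2 held constant, which would give a clean comparison with furan-2-yl.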